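Swapping the Aryl Group on the Sulfonate Oxygen

A few compounds are considered here, and "the series" means these few. Any claim that something is new, unique, unknown or untested is made for them only; others in the source may bear on it.

Compound 1 `Cc1ccccc1OS(=O)(=O)c1cccc(NC(=O)NCCCCl)c1` and compound 2 `Cc1ccccc1OS(=O)(=O)c1ccc(NC(=O)NCCCCl)cc1` share the same core and differ only in where the urea arm sits. In a functional assay on MCF7 cells (Homo sapiens) for cytotoxicity, read by sulforhodamine B assay, with a stated time of 48 h (a higher number here means a weaker inhibitor, a lower number a stronger inhibitor), compound 1 gives 27000 nM, and compound 2 gives 27000 nM, level with compound 1 within the scatter. Compound 3 `O=C(NCCCCl)Nc1ccc(S(=O)(=O)Oc2ccc(O)cc2)cc1` differs from compound 2 by 4-hydroxyphenyl in place of 2-methylphenyl on an oxygen. Among the compounds with values here, no measured pair shows this particular change. The step is therefore expected to be small and without a clear direction, no change at the digits printed from compound 2 to compound 3 (within the scatter). On that basis compound 3 is expected to give about 27000 nM, with a likely range from 9000 nM to 80000 nM.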

Compound 3, half-maximal inhibitory concentration: 51000 nM
The estimate for compound 3 lay 1.9-fold (0.28 log units) below the measured number; measured number inside the range.
By their numbers in this assay, from the lowest: compounds 1, 2 and 3 (each within the scatter of the next).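

In this assay, placing 4-hydroxyphenyl in place of 2-methylphenyl on the oxygen attached to the sulfonyl sulfur gives a 1.9-fold higher number from compound 2 to compound 3 (0.28 log units; within the scatter), so compound 2 and compound 3 cannot be told apart here. Where the earlier compounds varied only the urea arm, this is the first reading of a change on this oxygen, and the added hydrogen-bond donor and acceptor leave the result within the scatter. No supporting measurement bears on this result.

From the compounds shown here alone, whether a phenyl ring carrying an amine or a carboxylic acid would move the number beyond the scatter remains open. Also open, going by these compounds, is whether 4-hydroxyphenyl would read the same with the urea arm placed as in compound 1.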